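Cyclobutyl to neopentyl on the imidazole chain

This account rests on a few compounds, and the source may have more. Where it says the series, first, only, none or still open, it means among the compounds named here.

Measured compounds and their values:
Compound 1 `O=C(O)c1ccccc1-c1ccc(CCc2ncc(CC3CCC3)[nH]2)cc1`: 588 nM
Compound 2 `O=C(O)c1ccccc1-c1ccc(CCc2ncc(CCc3ccccc3)[nH]2)cc1`: 1320 nM
Compound 3 `CCCCc1cnc(CCc2ccc(-c3ccccc3C(=O)O)cc2)[nH]1`: 2710 nM

In an in vitro functional assay on cells for agonist activity at Bombesin receptor subtype-3 (Homo sapiens), read by luminescence and calcium flux (a lower number here means that less compound is needed, a higher number that more compound is needed for the effect), compound 1 gives the lowest number of the three. The two steps away from it both raise the number: a 2.2-fold higher number from compound 1 to compound 2 (0.35 log units; beyond the scatter) and a 4.6-fold higher number from compound 1 to compound 3 (0.66 log units; beyond the scatter). Between the other two, a 2.1-fold higher number from compound 2 to compound 3 (0.31 log units; beyond the scatter).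

Compound 4 `CC(C)(C)CCc1cnc(CCc2ccc(-c3ccccc3C(=O)O)cc2)[nH]1` has not yet been measured. It differs from compound 1 in one place: neopentyl in place of cyclobutyl on a saturated chain carbon bound to an aromatic carbon. The bearing steps are those from compound 1 to compounds 2 and 3, both modest rises in the number, with the open-chain propyl of compound 3 giving the larger one. Neopentyl is likewise an open chain at the same place, but with a different shape from propyl, so a rise of modest size is expected, with real uncertainty in how large.

For compound 4 the expected value in this assay is 1300 nM, with a range from 500 nM to 3400 nM, which is an estimated step of a 2.2-fold higher number from compound 1 to compound 4 (0.34 log units; beyond the scatter).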

Compound 4, half-maximal effective concentration: 39 nM
Compound 4: middle estimate off by 33-fold (1.52 log units), on the high side, outside the stated range (below it).
By their numbers in this assay, from the lowest: compound 4; then compound 1; then compound 2; then compound 3.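

In this assay, an open chain at this place is not a liability in itself: neopentyl in place of cyclobutyl gives a 15-fold lower number from compound 1 to compound 4 (1.18 log units; beyond the scatter), although both earlier steps away from compound 1 raised the number. At the saturated chain carbon two bonds along the chain from an aromatic carbon, tert-butyl in place of ethyl gives a 69-fold lower number from compound 3 to compound 4 (1.84 log units; beyond the scatter), and tert-butyl in place of phenyl gives a 34-fold lower number from compound 2 to compound 4 (1.53 log units; beyond the scatter), so the group at the end of the chain matters far more than compounds 1 to 3 suggested. The data on hand offer no explanation for this result.

From the compounds shown here alone, it remains open whether the low number is specific to tert-butyl or would also appear with isopropyl, cyclopentyl or trimethylsilyl at the same place. Going by these compounds, it is equally open how a longer chain ending in tert-butyl would behave.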